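A few compounds are considered here, and "the series" means these few. Any claim that something is new, unique, unknown or untested is made for them only; others in the source may bear on it.

Two compounds, both built around an amidine-bearing aromatic unit, have been measured in an assay on Sf9 cells for inhibition of kallikrein-5 (Homo sapiens), read by fluorescence, with stated times of 30 s and 5 min; on this read-out lower numbers stand for stronger inhibition and higher numbers for weaker inhibition. Compound 1 `N=C(N)c1ccc(NCc2nc(-c3ccccc3)c[nH]2)cc1` gives 6310 nM in this assay, and compound 2 `Cn1c(CNc2ccc(C(=N)N)cc2)nc2ccccc21` gives 15800 nM. Of these two numbers, compound 1 has the lower one, and its gap to compound 2 lies beyond the usual scatter, so compound 1 stands as the stronger inhibitor of the pair. Compound 3 `N=C(N)c1ccc(NCc2nc(-c3ccccc3)c[nH]2)cc1OCC(=O)NC1CC1` has not yet been measured. It differs from compound 1 in a single place: (cyclopropylcarbamoyl)methoxy in place of hydrogen on an aromatic carbon. Going by the values given here, no measured pair shows this kind of change, so there is no earlier step to lean on, and a move in either direction remains possible. The expectation here is a moderate move toward a lower number, with an expected step of a 2.5-fold lower number from compound 1 to compound 3 (0.40 log units; beyond the scatter). For compound 3 the estimated value in this assay is 2500 nM, with a likely range from 600 nM to 10000 nM.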

Compound 3, half-maximal inhibitory concentration: 79.4 nM
Beside the measured number, compound 3's estimate is 31-fold (1.50 log units) above it; the whole stated range lies above it.
By their numbers in this assay, from the lowest: compound 3; then compound 1; then compound 2.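

In this assay, the aromatic carbon ortho to a group of 3 heavy atoms and meta to a large group proves highly sensitive to substitution: (cyclopropylcarbamoyl)methoxy in place of hydrogen gives a 79-fold lower number from compound 1 to compound 3 (1.90 log units; beyond the scatter). Going by these compounds alone, compound 1 and compound 2 offered no single-place step, so this is the first view of any change at this position, and the step is large and well beyond the scatter. The data shown give no measured explanation for it.

Still open is which part of the entering group accounts for the step: the cyclopropyl ring, the amide, or the oxygen attached to the aromatic ring. A plain methoxy, a carboxylic acid or a longer chain at this position would help separate these parts.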